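The source may report more compounds than this note shows. Statements on the series, on what has been measured and on what is new or still open speak of the compounds shown alone.

Measured compounds:
compound 1 `NS(=O)(=O)c1ccc(-n2nc(-c3ccc(Cl)cc3)cc2-c2cc(O)ccc2O)cc1` with 39100 nM
compound 2 `CC(=O)NS(=O)(=O)c1ccc(-n2nc(-c3ccccc3)cc2-c2cc(O)ccc2O)cc1` with 100000 nM
compound 3 `NS(=O)(=O)c1ccc(-n2nc(-c3ccc(Cl)cc3)cc2C2=CC(=O)C=CC2=O)cc1` with 71100 nM

In a functional assay on cells (Cancer cell lines, Homo sapiens) for cytotoxicity, read by sulforhodamine B assay, with a stated time of 48 h (a higher number here means a weaker inhibitor of growth, a lower number a stronger inhibitor of growth), compound 1 gives 39100 nM and compound 3 gives 71100 nM. The two differ by a group of 8 heavy atoms (6 carbon, 2 oxygen; one six-membered non-aromatic ring of carbon only) in place of a group of 8 heavy atoms (6 carbon, 2 oxygen; one six-membered aromatic ring of carbon only), on an aromatic carbon and the step is a 1.8-fold higher number from compound 1 to compound 3 (0.26 log units; within the scatter), so this change left the number essentially where it was. Compound 2 gives 100000 nM, a higher number than compound 1 beyond the scatter, while its gap to compound 3 lies within the scatter. How the core of compound 2 differs from that of compound 1 is not broken down here.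

Compound 4 `CC(=O)NS(=O)(=O)c1ccc(-n2nc(-c3ccccc3)cc2C2=CC(=O)C=CC2=O)cc1` has not been measured. It differs from compound 2 by a group of 8 heavy atoms (6 carbon, 2 oxygen; one six-membered non-aromatic ring of carbon only) in place of a group of 8 heavy atoms (6 carbon, 2 oxygen; one six-membered aromatic ring of carbon only), on an aromatic carbon. This is the same kind of change as the one from compound 1 to compound 3, and it occurs twice among these compounds; the surroundings differ in that the neighbouring ring atom bears a large group rather than a 4-sulfamoylphenyl group, and the ring atom two ring bonds away bears a phenyl group rather than a 4-chlorophenyl group.

Given that the earlier change produced only a 1.8-fold higher number from compound 1 to compound 3 (0.26 log units; within the scatter), compound 4 is expected to sit close to compound 2, and the step from compound 2 to compound 4 is estimated at a 1.5-fold higher number from compound 2 to compound 4 (0.18 log units; within the scatter). Because compound 2 already gives 100000 nM, a weakly active result is expected. Compound 4 is estimated at 150000 nM, within 70000 nM to 300000 nM.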

Compound 4, concentration for total growth inhibition: 100000 nM
Compound 4: the middle estimate sits 1.5-fold (0.18 log units) above what was measured; measured number inside the range.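

In this assay, putting the non-aromatic ring of carbon only in place of the 2,5-dihydroxyphenyl group gives no change at the digits printed from compound 2 to compound 4 (within the scatter), so this change again leaves the number essentially where it was. Set beside the earlier case, the change behaves alike on the two cores: the same change on two cores in this assay, a 1.8-fold higher number (0.26 log units; within the scatter) from compound 1 to compound 3 and no change at the digits printed (within the scatter) from compound 2 to compound 4, 1.8-fold (0.26 log units) apart, within the scatter of two such steps. Going by these compounds alone, this shows only that the change carried from one core to the other in these two pairs without a step beyond the scatter; it does not show that the change would be as quiet on any further core, and the two pairs cannot tell whether the phenyl or 4-chlorophenyl group, or the other difference between the cores, has any bearing on it.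

The compounds shown leave open how the number would respond to a different group on that same ring carbon, such as a phenyl ring bearing a carboxylic acid or an amine, or to a 4-methoxyphenyl group in place of the 4-chlorophenyl group. They also leave open what the same change would do on a core that combines the 4-chlorophenyl group of compound 1 with the acetyl-bearing sulfonamide of compound 2.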